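The source may report more compounds than this note shows. Statements on the series, on what has been measured and on what is new or still open speak of the compounds shown alone.

Among the compounds with values here, in a toxicity assay on HEK-293T cells (Homo sapiens) for cytotoxicity, read by MTT assay, with a stated time of 72 h (a lower number here means a stronger inhibitor, a higher number a weaker inhibitor), three compounds that share one core have numbers so far. Compound 1 `O=C1c2c[n+]([O-])c3ccccc3c2C(=O)c2c1c1ccccc1n2Cc1cn(CC(O)CO)nn1` gives 760 nM, compound 2 `CC1(C)OC[C@@H](Cn2cc(Cn3c4c(c5ccccc53)C(=O)c3c[n+]([O-])c5ccccc5c3C4=O)nn2)O1` gives 6020 nM, and compound 3 `CN1CCN(CCCn2c3c(c4ccccc42)C(=O)c2c[n+]([O-])c4ccccc4c2C3=O)CC1` gives 170 nM, the lowest of the three.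

Compound 4 `O=C1c2c[n+]([O-])c3ccccc3c2C(=O)c2c1c1ccccc1n2Cc1cn(C[C@@H](O)CO)nn1` has not yet been measured. Moving to it from compound 3 exchanges one group on a saturated chain carbon bound to an aromatic nitrogen: 1-(2,3-dihydroxypropyl)-1H-1,2,3-triazol-4-yl in place of 2-(4-methylpiperazin-1-yl)ethyl on a saturated chain carbon bound to an aromatic nitrogen. The incoming 1-(2,3-dihydroxypropyl)-1H-1,2,3-triazol-4-yl group is already present in compound 1, although there its stereocentre is not defined.

The most relevant evidence is a 4.5-fold lower number from compound 1 to compound 3 (0.65 log units; beyond the scatter), a modest step that makes the same exchange in the opposite direction. A second modest step, a 7.9-fold higher number from compound 1 to compound 2 (0.90 log units; beyond the scatter), places 2,2-dimethyl-1,3-dioxolan-4-yl where 1,2-dihydroxyethyl stood. It does not make the exchange in question, but it shows that the number can shift with a change at that end of the group, so it widens the range. No measurement isolates the effect of defining the stereocentre.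

A modest rise in this assay is therefore expected, roughly undoing the first step. The estimated step is a 4.4-fold higher number from compound 3 to compound 4 (0.64 log units; beyond the scatter). For compound 4 the expected value is 750 nM, with an estimated range from 330 nM to 1800 nM.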

Compound 4, half-maximal inhibitory concentration: 2030 nM
Compound 4: the middle estimate sits 2.7-fold (0.43 log units) below what was measured; the measured number lies above the stated range.
By their numbers in this assay, from the lowest: compound 3; then compound 1; then compound 4; then compound 2.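

In this assay the exchange of the 2-(4-methylpiperazin-1-yl)ethyl group gives a 12-fold higher number from compound 3 to compound 4 (1.08 log units; beyond the scatter), so with the stereocentre defined, the incoming group raises the number further than the step involving compound 1 alone had shown. Freeing the 1,2-dihydroxyethyl end from its 2,2-dimethyl-1,3-dioxolan-4-yl form still lowers the number, by a 3.0-fold lower number from compound 2 to compound 4 (0.47 log units; beyond the scatter), so this change at the far end of the group holds up with a defined stereocentre on both sides. The number at this position also moves with atoms and bonds unchanged, by a 2.7-fold higher number from compound 1 to compound 4 (0.43 log units; beyond the scatter), and the only thing separating that pair is this: the fact that one of compounds 1 and 4 is drawn with a defined configuration and the other without, at the place where they differ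

From the compounds shown here alone, what the opposite configuration at that stereocentre would give remains open, as does whether the undefined drawing of compound 1 stands for a blend of both forms. Also open, going by these compounds, is whether the low number of compound 3, 170 nM, depends on the 4-methylpiperazin-1-yl ring itself, or whether a morpholine or a dimethylamino group at the end of the same chain would give a similar number.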